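A few compounds are considered here, and "the series" means these few. Any claim that something is new, unique, unknown or untested is made for them only; others in the source may bear on it.

Among the three compounds measured in a functional assay on a subcellular fraction from brain (Rattus norvegicus) for inhibition, read by scintillation counting, with a stated time of 5 min (on this read-out higher numbers stand for weaker inhibition and lower numbers for stronger inhibition), compound 3 `Cc1ccc(NC2=NCCC3(CCCCC3)S2)cc1` gives 31600 nM, the lowest of the three numbers. Compound 2 `Clc1ccc(NC2=NCCC3(CCCCC3)S2)cc1` gives 35500 nM, a value that sits within the scatter of compound 3, while compound 1 `Cc1ccc(NC2=NCCC3(CCCCC3)S2)cc1Cl` gives 89100 nM, the highest of the set. The two steps that reach compound 3 are of unequal size: a 2.8-fold lower number from compound 1 to compound 3 (0.45 log units; beyond the scatter), and a 1.1-fold lower number from compound 2 to compound 3 (0.05 log units; within the scatter).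

Compound 4 `COc1ccc(NC2=NCCC3(CCCCC3)S2)cc1` differs from compound 3 in one place: methoxy in place of methyl on an aromatic carbon. Among the measured compounds shown here, no measured pair swaps methyl for methoxy, so the step can only be judged by analogy. For the measured compounds named here, the one substituent exchange at this position that is known, from compound 2 to compound 3, stayed within the scatter, and only the removal of chloro from compound 1 produced a step beyond it. The expectation for compound 4 in this assay is therefore a step of a 1.1-fold lower number from compound 3 to compound 4 (0.02 log units; within the scatter), with no clear direction. The estimated value for compound 4 is 30000 nM, within a range from 11000 nM to 85000 nM.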

Compound 4, half-maximal inhibitory concentration: 85100 nM
Compound 4: middle estimate off by 2.8-fold (0.45 log units), on the low side; measured number above the stated range.
By their numbers in this assay, from the lowest: compounds 3 and 2 (each within the scatter of the next); then compounds 4 and 1 (each within the scatter of the next).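

In this assay the place para to a large group turns out not to be indifferent to its substituent: chloro and methyl had stayed within the scatter of each other, yet methoxy gives a 2.7-fold higher number from compound 3 to compound 4 (0.43 log units; beyond the scatter) and a 2.4-fold higher number from compound 2 to compound 4 (0.38 log units; beyond the scatter) in the same direction. Among compound 2, compound 3 and compound 4, weaker inhibition therefore goes with methoxy, the only one of these three groups that carries an oxygen. Nothing available explains this step.

As far as these compounds go, whether the step follows the oxygen itself or the extra heavy atom that comes with it stays open. A hydroxy group, an amine or a longer chain such as ethoxy at this place would bear on that question.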